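The source may report more compounds than this note shows. Statements on the series, on what has been measured and on what is new or still open speak of the compounds shown alone.

Of the compounds shown here, three have so far been measured in an assay on Sf9 cells for inhibition of Amine oxidase [flavin-containing] B (Homo sapiens), with stated times of 15 min and 60 min; on this read-out lower numbers stand for stronger inhibition and higher numbers for weaker inhibition. Compound 1 `Cc1cc(OCc2cccc(F)c2)ccc1CN[C@@H](C)C(N)=O` and compound 2 `C[C@H](NCc1ccc(OCc2cccc(F)c2)cc1F)C(N)=O` are built on the same core and differ in a single place, described as methyl in place of fluoro on an aromatic carbon. In this assay compound 2 gives 61 nM, and compound 1 gives 69 nM, so this exchange produced a 1.1-fold higher number from compound 2 to compound 1 (0.05 log units; within the scatter). Compound 3 `C#CCN(Cc1ccc(OCc2cccc(F)c2)cc1F)[C@@H](C)C(N)=O` carries a different core, and the difference between the two cores is propargyl in place of hydrogen on an amine nitrogen. In this assay compound 3 gives 93 nM, which corresponds to a 1.5-fold higher number from compound 2 to compound 3 (0.18 log units; within the scatter). All three numbers lie close together, and none of the steps among them exceeds the usual scatter.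

Compound 4 `C#CCN(Cc1ccc(OCc2cccc(F)c2)cc1C)[C@@H](C)C(N)=O` has not yet been measured in this assay. It differs from compound 3 by methyl in place of fluoro on an aromatic carbon. Among the compounds with values here, this is the same kind of change as the one from compound 2 to compound 1, though the surroundings are not described in identical words: in the earlier pair the site is ortho to a ((1-carbamoylethyl)amino)methyl group (7 heavy atoms), whereas here it is ortho to a large group; in both cases it is meta to a group of 9 heavy atoms. Because the earlier exchange gave a 1.1-fold higher number from compound 2 to compound 1 (0.05 log units; within the scatter), the corresponding exchange on the core of compound 3 is expected to stay within the scatter as well, and the expected step is a 1.1-fold higher number from compound 3 to compound 4 (0.03 log units; within the scatter). Compound 4 is therefore estimated to give about 100 nM in this assay, most likely between 50 nM and 200 nM.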

Compound 4, half-maximal inhibitory concentration: 320 nM
Estimate against measurement, compound 4: 3.2-fold (0.51 log units) below, and the stated range ends below it.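

In this assay, methyl in place of fluoro on the aromatic carbon gives a 3.4-fold higher number from compound 3 to compound 4 (0.54 log units; beyond the scatter), and propargyl in place of hydrogen on the amine nitrogen gives a 4.6-fold higher number from compound 1 to compound 4 (0.67 log units; beyond the scatter). The size of the methyl exchange therefore does not carry over from one core to the other: the same change on two cores in this assay, a 1.1-fold higher number (0.05 log units; within the scatter) from compound 2 to compound 1 and a 3.4-fold higher number (0.54 log units; beyond the scatter) from compound 3 to compound 4, 3.0-fold (0.48 log units) apart, beyond the scatter of two such steps

Read the other way, the same four compounds say the same of propargyl, so this is one observation rather than two, and it shows only that these two changes do not simply add up here, not why they do not or whether the same holds for any other compound: the same change on two cores in this assay, a 1.5-fold higher number (0.18 log units; within the scatter) from compound 2 to compound 3 and a 4.6-fold higher number (0.67 log units; beyond the scatter) from compound 1 to compound 4, 3.0-fold (0.48 log units) apart, beyond the scatter of two such steps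

The compounds shown leave open whether the weaker inhibition of compound 4 is particular to methyl at this aromatic carbon, which a chloro or a methoxy group in its place on the core of compound 3 could test. They also leave open whether it is particular to propargyl, which an ethyl or an allyl group on the amine nitrogen of compound 1 could test.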